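Swapping methoxy for methyl on compound 1

The source may report more compounds than this note shows. Statements on the series, on what has been measured and on what is new or still open speak of the compounds shown alone.

Among the compounds with values here, in a functional assay on Huh-7 cells (Homo sapiens) for inhibition, read by MTT assay, with a stated time of 48 h (on this read-out higher numbers stand for weaker inhibition and lower numbers for stronger inhibition), compound 1 (`COc1ccc(CNC(=O)/C=C/c2coc3cc(O)ccc3c2=O)cc1`) gives 8430 nM and compound 2 (`COc1ccc(CNC(=O)/C=C/c2coc3cc(OC)ccc3c2=O)cc1`) gives 7570 nM as the only two numbers so far. They lie within the scatter of each other, so compound 1 holds no clear rank. Compound 3 (`Cc1ccc(CNC(=O)/C=C/c2coc3cc(O)ccc3c2=O)cc1`) keeps the core of compound 1 but has methyl in place of methoxy on an aromatic carbon, that is, 4-methoxyphenyl becomes 4-methylphenyl (methyl in place of methoxy on an aromatic carbon). Within the data shown here, the one measured step (a 1.1-fold lower number from compound 1 to compound 2 (0.05 log units; within the scatter)) is a different change, methyl in place of hydrogen on an oxygen on an aromatic ring, so it bears only indirectly. Among the measured compounds shown here, no measurement yet tests the new swap, and in this assay no shift beyond the scatter is expected. The expected step is a 1.1-fold lower number from compound 1 to compound 3 (0.02 log units; within the scatter) in this estimate. For compound 3 the estimated value is 8000 nM with 3500 nM and 18000 nM as the ends of the expected range.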

Compound 3, half-maximal inhibitory concentration: > 100000 nM
Compound 3: no number, only a limit (the forecaster's own chance of this, stated with the estimate: 5%); middle value at least 12-fold (1.09 log units) from the limit.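

In this assay, compound 3 gives > 100000 nM, which is a limit of the assay and not a number. The step reads an at least 11-fold higher number from compound 1 to compound 3 (1.07 log units; beyond the scatter), so inhibition is clearly weaker with 4-methylphenyl than with 4-methoxyphenyl. The earlier pair changed only the group on the oxygen of the shared core and stayed within the scatter, whereas this result shows that the read-out can respond strongly to the group on the aromatic carbon of the six-membered ring.

The compounds shown leave open whether another group at this place, such as hydroxyl, an amine or the longer ethoxy chain, would keep the read-out close to that of compound 1. They also leave open how weak compound 3 really is, since only a lower bound on the step can be given: the limit of > 100000 nM in this assay, at which 1 of the 3 values shown sits.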